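The source may report more compounds than this note shows. Statements on the series, on what has been measured and on what is new or still open speak of the compounds shown alone.

Measured compounds: compound 1 `CO/N=c1\[nH]cnc2c1[n+](C/C=C(\C)CC/C=C(\C)CC/C=C(\C)CCC=C(C)C)cn2CCC#N` gives 3960 nM in a functional assay on cells (Homo sapiens) for cytotoxicity; a lower number here means a stronger inhibitor, a higher number a weaker inhibitor; compound 2 `CC(C)=CCC/C(C)=C/CC/C(C)=C/CC/C(C)=C/C[n+]1cn(CCC#N)c2nc[nH]/c(=N\OCc3ccccc3)c21` gives 9460 nM; compound 3 `CO/N=c1\[nH]cnc2c1[n+](C/C=C(\C)CCCC(C)CCCC(C)CCCC(C)C)cn2C` gives 3750 nM.

The difference between the core of compound 1 and the core of compound 3 is not broken down here. Compound 1 and compound 3 give values within the scatter of each other, so neither is set apart from the other. Between compound 1 and compound 2 the change is phenyl in place of hydrogen on a saturated chain carbon bound to an oxygen, and it made a step of a 2.4-fold higher number from compound 1 to compound 2 (0.38 log units; beyond the scatter). Compound 4 `C/C(=C\C[n+]1cn(C)c2nc[nH]/c(=N\OCc3ccccc3)c21)CCCC(C)CCCC(C)CCCC(C)C` is not yet measured; it differs from compound 3 by phenyl in place of hydrogen on a saturated chain carbon bound to an oxygen, the same change, at the same place. Because the earlier step was a 2.4-fold higher number from compound 1 to compound 2 (0.38 log units; beyond the scatter), compound 4 is expected to show a step of a 2.4-fold higher number from compound 3 to compound 4 (0.38 log units; beyond the scatter) from compound 3, a weakening of similar size. Compound 4 is therefore estimated at 9000 nM, with a likely range from 4500 nM to 18000 nM.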

Compound 4, half-maximal inhibitory concentration: 7070 nM
Estimate against measurement, compound 4: 1.3-fold (0.10 log units) above, within the range that was stated.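

In this assay, the exchange of methoxy for benzyloxy gives a 1.9-fold higher number from compound 3 to compound 4 (0.28 log units; within the scatter). Set beside the same change on the other core, this step cannot be told apart from the earlier one: the same change on two cores in this assay, a 2.4-fold higher number (0.38 log units; beyond the scatter) from compound 1 to compound 2 and a 1.9-fold higher number (0.28 log units; within the scatter) from compound 3 to compound 4, 1.3-fold (0.10 log units) apart, within the scatter of two such steps. The change thus carries over between these two cores with no detectable difference in size, although only the earlier step alone lies beyond the scatter, and two pairs do not show that it would hold on any further core.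

The compounds shown leave open how other groups on the oxygen, such as ethyl, a longer chain or a benzyl ring bearing an amine, would compare. They also do not separate the parts of the difference between the two cores.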